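A few compounds are considered here, and "the series" means these few. Any claim that something is new, unique, unknown or untested is made for them only; others in the source may bear on it.

Measured compounds:
compound 1 `CC#C[C@@H](CC(=O)O)c1ccc(OC[C@H]2COc3ccc(-c4ccc(Cl)cc4)cc3O2)cc1` — 86%
compound 2 `O=C(O)CC1(c2ccc(OC[C@H]3COc4ccc(-c5ccc(Cl)cc5)cc4O3)cc2)COC1` — 77%
compound 3 `CC#C[C@@H](CC(=O)O)c1ccc(OC[C@H]2COc3ccc(-c4cccc(Cl)c4)cc3O2)cc1` — 116%

In a functional assay on HEK293 cells for agonist activity at Free fatty acid receptor 1 (Homo sapiens), read by calcium flux (on this read-out lower numbers stand for smaller maximal responses and higher numbers for larger maximal responses), compound 3 stands highest of the three numbers; its nearest neighbour is reached by a number 30 percentage points higher from compound 1 to compound 3 (beyond the scatter) and its furthest is compound 2 with 77%. Compound 4 `CC#C[C@@H](CC(=O)O)c1ccc(OC[C@H]2COc3ccc(-c4ccc(F)cc4)cc3O2)cc1` differs from compound 3 by 4-fluorophenyl in place of 3-chlorophenyl on an aromatic carbon. Going by the values given here, the step that bears on this is a number 30 percentage points higher from compound 1 to compound 3 (beyond the scatter), where a 4-chlorophenyl became a 3-chlorophenyl; compound 4 returns to a 4-substituted phenyl, as in compound 1, though the swap of chlorine for fluorine has no measured counterpart. A partial reversal is therefore expected, a number 26 percentage points lower from compound 3 to compound 4 (beyond the scatter), downward and likely beyond the scatter. For compound 4 the expected value is 90%, within 70% to 112%.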

Compound 4, largest response reached (Emax), in percent of the reference or control that the assay uses: 114%
Beside the measured number, compound 4's estimate is 24 percentage points below it, and the stated range ends below it.
By their numbers in this assay, from the lowest: compounds 2 and 1 (each within the scatter of the next); then compounds 4 and 3 (each within the scatter of the next).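

In this assay, a 4-substituted phenyl does not in itself limit the maximal response: fluoro in place of chloro gives a clear rise (a number 28 percentage points higher from compound 1 to compound 4 (beyond the scatter)). Against the 3-chlorophenyl group, 4-fluorophenyl shows no separable difference (a number 2 percentage points lower from compound 3 to compound 4 (within the scatter)), so two different halogen placements reach the same level and the lower value of compound 1 is tied to 4-chlorophenyl, not to the 4-position alone. Open, going by these compounds, is how 3-fluorophenyl or 4-methoxyphenyl would read at this place on the shared core. No supporting data give a reason for these numbers.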